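One Methyl More on the Amide Chain of Compound 3

The compounds below may be only part of what the source reports. "The series", "measured", "known", "first", "only" and "open" are said of these compounds alone.

Compound 1 `O=c1cc(-c2ccccc2)[nH]c(=O)n1O`: in an assay on isolated protein for inhibition of deoxyribonuclease-1 (Homo sapiens) (on this read-out higher numbers stand for weaker inhibition and lower numbers for stronger inhibition), compound 1 gives > 100000 nM, which is a limit of the assay and not a number.
Compound 2 `COc1nc(-c2cccs2)nc(C(=O)O)c1O`: for compound 2 in this assay no result is reported, "not determined" (no result reported).
Compound 3 `CCCNC(=O)c1nc(-c2cccs2)[nH]c(=O)c1O`: in this assay compound 3 gives > 100000 nM, again a limit of the assay and not a number.

For the measured compounds named here, two of the three entries thus sit at the same limit, (the limit of > 100000 nM in this assay, at which 2 of the 3 values shown sit), and no two measured compounds differ in a single place, so no measured step exists. Compound 3 stands where most of what is shown stands: at a limit, without a number of its own, while the remaining entry gives no result at all.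

Compound 4 `CCC(C)NC(=O)c1nc(-c2cccs2)[nH]c(=O)c1O` is made from compound 3 by one change: methyl in place of hydrogen on a saturated chain carbon bound to an amide-type nitrogen and a saturated chain carbon. Going by the values given here, with no measured step to lean on, the expected step is a number no higher from compound 3 to compound 4 (the limit leaves the size open), that is, none beyond the usual scatter. Compound 4 is thus estimated at 100000 nM, with a range from 30000 nM to 300000 nM.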

Compound 4, half-maximal inhibitory concentration: > 100000 nM
Compound 4 ended at the assay's limit (the forecaster's own chance of this, stated with the estimate: 80%); the middle value lies on the limit itself.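

In this assay compound 3 and compound 4 both end at a limit of the assay and not at a number, so no step can be read between them. The compounds shown leave open how strongly either one inhibits the enzyme, and whether the added methyl makes any difference.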